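The source may report more compounds than this note shows. Statements on the series, on what has been measured and on what is new or still open speak of the compounds shown alone.

Compound 1 `CCCCNc1cc(-c2ccccc2)nc2cc(OC)cc(OC)c12` carries a butylamino group on the shared core, and in a functional assay on DU-145 cells (Homo sapiens) for inhibition, read by MTT assay, with a stated time of 72 h (on this read-out higher numbers stand for weaker inhibition and lower numbers for stronger inhibition), compound 1 gives 4630 nM. Compound 2 `COc1cc(OC)c2c(-n3ccnc3)cc(-c3ccccc3)nc2c1` is reported in this assay only as a limit, > 100000 nM. From the compounds shown here alone, compound 3 `COc1cc(OC)c2c(N3CCCCC3)cc(-c3ccccc3)nc2c1` likewise stands only at a limit, > 100000 nM, so where it truly lies past that boundary is unknown. The steps of an at least 21-fold higher number from compound 1 to compound 2 (1.33 log units; beyond the scatter) and an at least 21-fold higher number from compound 1 to compound 3 (1.33 log units; beyond the scatter) are both large, whereas a step that the two limits leave unreadable from compound 2 to compound 3. Compound 4 `COc1cc(OC)c2c(NC3CCCCC3)cc(-c3ccccc3)nc2c1` differs from compound 3 by cyclohexylamino in place of piperidin-1-yl on an aromatic carbon. Among the measured compounds shown here, compound 1, with 4630 nM, is the only compound with a readable number and also carries an amino group with a hydrogen-bond donor, so compound 4 is expected to move back toward it, an estimated at least 8.3-fold lower number from compound 3 to compound 4 (0.92 log units; beyond the scatter). Compound 4 is therefore estimated at 12000 nM, between 2500 nM and 100000 nM.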

Compound 4, half-maximal inhibitory concentration: 5470 nM
Compound 4: middle estimate off by 2.2-fold (0.34 log units), on the high side; the range from low to high includes it.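

Cyclohexylamino, which carries a hydrogen-bond donor, gives a readable number at this position, with an at least 18-fold lower number from compound 3 to compound 4 (1.26 log units; beyond the scatter) and an at least 18-fold lower number from compound 2 to compound 4 (1.26 log units; beyond the scatter). Both sizes are only minimums because compound 2 and compound 3 stand at a limit of the assay: the limit of > 100000 nM in this assay, at which 2 of the 4 values shown sit. With a 1.2-fold higher number from compound 1 to compound 4 (0.07 log units; within the scatter), cyclohexyl and butyl on this nitrogen cannot be told apart, so a ring and an open chain both fit here.

From the compounds shown here alone, how a phenylamino group or an unsubstituted amine on this aromatic carbon would read stays open. The compounds shown also cannot separate the role of the hydrogen on nitrogen from other differences between these groups.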